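This account rests on a few compounds, and the source may have more. Where it says the series, first, only, none or still open, it means among the compounds named here.

Compound 1 `Cn1c(N)c(-c2nc3ccccc3[nH]2)c2nc(C#N)c(C#N)nc21` gives > 50000 nM.
Compound 2 `CCn1c(N)c(-c2nc3ccccc3[nH]2)c2nc(C#N)c(C#N)nc21` gives > 50000 nM.
Compound 3 `CN1CCN(CCn2c(N)c(-c3nc4ccccc4[nH]3)c3nc(C#N)c(C#N)nc32)CC1` gives 9110 nM.

In a functional assay on cells (Homo sapiens) for antiproliferative activity, read by MTT assay, with a stated time of 48 h (a higher number here means a weaker inhibitor, a lower number a stronger inhibitor), compound 1 stands only at a limit, not at a number: the limit of > 50000 nM in this assay, at which 2 of the 3 values shown sit. The same holds for compound 2, so the step that the two limits leave unreadable from compound 1 to compound 2 cannot be read. Compound 3, which carries a longer chain on the same position, gives a real number, and the step of an at least 5.4-fold lower number from compound 1 to compound 3 (0.73 log units; beyond the scatter) is the only readable one in this set.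

Compound 4 `CCN(CC)CCCCn1c(N)c(-c2nc3ccccc3[nH]2)c2nc(C#N)c(C#N)nc21` is built on the core of compound 1 with the change (3-(diethylamino)propyl in place of hydrogen on a saturated chain carbon bound to an aromatic nitrogen). This resembles the change from compound 1 to compound 3, where a chain carrying a nitrogen also enters at that position, so a drop of a similar size is expected, roughly an at least 5.0-fold lower number from compound 1 to compound 4 (0.69 log units; beyond the scatter). Compound 4 is therefore estimated at 10000 nM, with a likely range from 3000 nM to 40000 nM.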

Compound 4, half-maximal inhibitory concentration: 640 nM
Estimate against measurement, compound 4: 16-fold (1.19 log units) above; measured number outside the range, below it.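

Placing 3-(diethylamino)propyl on the saturated chain carbon bound to an aromatic nitrogen gives an at least 78-fold lower number from compound 1 to compound 4 (1.89 log units; beyond the scatter) in this assay, and the matching comparison with the ethyl compound gives an at least 78-fold lower number from compound 2 to compound 4 (1.89 log units; beyond the scatter). Compound 3 had shown a real value at this position, but this much larger step shows that the position can carry a chain ending in an amine with far stronger activity in this assay. The chain's identity also matters, as two chains that both carry nitrogen still give a 14-fold lower number from compound 3 to compound 4 (1.15 log units; beyond the scatter).

On these data alone, compound 1 and compound 2 stand at a limit, not at a number, so the step between them cannot be read and the full size of their other steps stays open because of it: the limit of > 50000 nM in this assay, at which 2 of the 4 values shown sit. Compound 3 and compound 4 differ in both chain length and amine, so a butyl chain ending in 4-methylpiperazin-1-yl or an ethyl chain ending in diethylamino would be needed to separate the two.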